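The source may report more compounds than this note shows. Statements on the series, on what has been measured and on what is new or still open speak of the compounds shown alone.

Measured in a functional assay on HepG2 cells (Homo sapiens) for antiproliferative activity, read by MTT assay, with a stated time of 48 h; a lower number here means a stronger inhibitor, a higher number a weaker inhibitor:
- compound 1 `COc1ccc(/C=C/c2cc(OC)cc(OC)c2/C=C/C(=O)c2ccc(C)cc2)cc1` gives 4.8 ug/mL
- compound 2 `COc1ccc(/C=C/c2cc(OC)cc(OC)c2/C=C/C(=O)c2cccc(Cl)c2)cc1` gives 9.5 ug/mL
- compound 3 `COc1ccc(/C=C/c2cc(OC)cc(OC)c2/C=C/C(=O)c2ccc(Br)cc2)cc1` gives 12.9 ug/mL

Compound 3 is separated from compound 1 by a modest step, a 2.7-fold higher number from compound 1 to compound 3 (0.43 log units; beyond the scatter). It is not separated from compound 2, given a 1.4-fold higher number from compound 2 to compound 3 (0.13 log units; within the scatter).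

Compound 4 `COc1ccc(/C=C/c2cc(OC)cc(OC)c2/C=C/C(=O)c2ccc(Cl)cc2)cc1` is next, with the change chloro in place of bromo on an aromatic carbon, para to a large group. Among the compounds with values here, no measured pair isolates this exchange. The nearest evidence is a 1.4-fold higher number from compound 2 to compound 3 (0.13 log units; within the scatter), which also involves chloro and bromo, though the place changes too. The step of a 2.7-fold higher number from compound 1 to compound 3 (0.43 log units; beyond the scatter) involves methyl and says less here. No step beyond the scatter is therefore expected in this assay, and no direction is favoured. The expected step is a 1.2-fold lower number from compound 3 to compound 4 (0.07 log units; within the scatter). Compound 4 is estimated at 11 ug/mL, with an expected range of 6 ug/mL to 20 ug/mL.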

Compound 4, half-maximal inhibitory concentration: 13.6 ug/mL
The estimate for compound 4 lay 1.2-fold (0.09 log units) below the measured number; the range from low to high includes it.
By their numbers in this assay, from the lowest: compounds 1, 2, 3 and 4 (each within the scatter of the next, the first and the last beyond it).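

With chloro in place of bromo on the aromatic carbon para to a large group, this assay gives a 1.1-fold higher number from compound 3 to compound 4 (0.02 log units; within the scatter), so the two halogens are not separated at this position. The 4-chlorophenyl in place of 3-chlorophenyl gives a 1.4-fold higher number from compound 2 to compound 4 (0.16 log units; within the scatter), so the place of the chlorine is not resolved either, whereas chloro in place of methyl gives a 2.8-fold higher number from compound 1 to compound 4 (0.45 log units; beyond the scatter), a second halogen set apart from methyl at this position. Nothing available accounts for these steps. Open, as far as these compounds go, is whether an amine or a carboxylic acid at this position would fall with methyl, with the halogens, or outside both.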